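Swapping the Amine on a Fused Core: Clearance Outlook

This account rests on a few compounds, and the source may have more. Where it says the series, first, only, none or still open, it means among the compounds named here.

Compound 1 `CCc1ccc(-c2c(-c3nn(C)c4ncnc(N5CCN(C)CC5)c34)cnn2C)cc1` was tested in an ADME assay on microsomes from liver (Homo sapiens) for metabolic stability (on this read-out lower numbers stand for slow clearance and higher numbers for fast clearance), where compound 1 gives 60 mL/min/kg. Among the three measured compounds this is the second highest number. The nearest is compound 2 `Cn1ncc(-c2nn(C)c3ncnc(N4CCC4)c23)c1-c1ccc(C2CC2)cn1`, which in this assay gives 53 mL/min/kg; the two values lie within the scatter of each other. The furthest is compound 3 `CC(C)Cc1nn(C)c2ncnc(N3Cc4ccccc4C3)c12`, which in this assay gives 123 mL/min/kg, a gap beyond the scatter. Compound 4 `CCc1ccc(-c2c(-c3nn(C)c4ncnc(N5CCCC5)c34)cnn2C)cc1` has not yet been measured. It differs from compound 1 in one place: pyrrolidin-1-yl in place of 4-methylpiperazin-1-yl on an aromatic carbon. Among the compounds with values here, no measured pair in this set shows the effect of exactly that exchange, so there is no directly comparable step to lean on. The closest guide is compound 2, whose value 53 mL/min/kg sits close to that of compound 1 despite a different small ring. The step is expected to be small, a 1.2-fold higher number from compound 1 to compound 4 (0.07 log units; within the scatter), perhaps slightly upward but not clearly beyond the scatter. Compound 4 is therefore estimated to give 70 mL/min/kg, with a range from 35 mL/min/kg to 140 mL/min/kg.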

Compound 4, clearance: 200 mL/min/kg
Compound 4: the middle estimate sits 2.9-fold (0.46 log units) below what was measured; the measured number lies above the stated range.
By their numbers in this assay, from the lowest: compounds 2 and 1 (each within the scatter of the next); then compounds 3 and 4 (each within the scatter of the next).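

In this assay, placing pyrrolidin-1-yl instead of 4-methylpiperazin-1-yl on this aromatic carbon gives a 3.3-fold higher number from compound 1 to compound 4 (0.52 log units; beyond the scatter). This position therefore matters for clearance: with the rest of the molecule unchanged, exchanging this one ring moves the number beyond the scatter. The exchange both removes a ring nitrogen with its methyl group and changes a six-membered ring to a five-membered one, and no measurement here bears on why the number rises.

On these data alone, a single pair cannot separate those two differences, so it remains open whether ring size or the extra nitrogen accounts for the step, a question that a piperidine or a morpholine on the same carbon could address. Also open, as far as these compounds go, is how an open-chain amine such as dimethylamino would behave there.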